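The compounds below may be only part of what the source reports. "The series", "measured", "known", "first", "only" and "open" are said of these compounds alone.

Of the compounds shown here, two built on a shared core have so far been tested in a functional assay on A549 cells (Homo sapiens) for cytotoxicity, read by MTT assay, with a stated time of 48 h; on this read-out lower numbers stand for stronger inhibition and higher numbers for weaker inhibition. Compound 1 `O=C(O)CN1C(=O)/C(=C/c2nc3ccccc3n2Cc2ccccc2F)SC1=S` gives 2670 nM. Compound 2 `COc1ccc2nc(/C=C3\SC(=S)N(CC(=O)O)C3=O)n(Cc3ccc(C)cc3)c2c1` gives 23600 nM, the highest of the two numbers, and its gap to compound 1 lies beyond the usual scatter of repeated measurements. Compound 3 `COc1ccc2nc(/C=C3\SC(=S)N(CC(=O)O)C3=O)n(Cc3ccccc3F)c2c1` has not yet been measured. It keeps the core of compound 2 and differs from it in one place: 2-fluorophenyl in place of 4-methylphenyl on a saturated chain carbon bound to an aromatic nitrogen. Going by the values given here, compound 1 carries the same 2-fluorobenzyl group, though on a different core, so the two measured compounds differ in more than one place and no clean single step is available. Given that compound 1 sits at 2670 nM, the change is expected to lower the number, by a 3.0-fold lower number from compound 2 to compound 3 (0.47 log units; beyond the scatter) in this assay. Compound 3 is therefore estimated at 8000 nM, within a range from 3000 nM to 25000 nM.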

Compound 3, half-maximal inhibitory concentration: 36200 nM
Estimate against measurement, compound 3: 4.5-fold (0.66 log units) below; measured number above the stated range.
By their numbers in this assay, from the lowest: compound 1; then compounds 2 and 3 (each within the scatter of the next).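

In this assay the change from 4-methylbenzyl to 2-fluorobenzyl gives a 1.5-fold higher number from compound 2 to compound 3 (0.19 log units; within the scatter) and so makes no readable difference on the core of compound 2. With 2-fluorobenzyl held constant, methoxy in place of hydrogen on an aromatic carbon gives a 14-fold higher number from compound 1 to compound 3 (1.13 log units; beyond the scatter) and is the only structural difference in this pair, so here the large change comes from the core rather than from the benzyl group. Nothing measured on these compounds explains either result.

Going by these compounds, whether methoxy has a similarly large effect when 4-methylbenzyl is present remains open. So does the outcome of placing a different group on that aromatic carbon, such as a chlorine atom or an amine, or of using an unsubstituted benzyl group on the chain.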